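A Furan in Place of an Isobutoxyphenyl Group

The compounds below may be only part of what the source reports. "The series", "measured", "known", "first", "only" and "open" are said of these compounds alone.

Compound 3 has the structure `CC(C)COc1cccc(-c2ccc(C(=O)N(Cc3cccc(OCCCCCC(=O)O)c3)C(C)C)cc2)c1`. In an ADME assay on Raji cells (Homo sapiens) for cytotoxicity, read by CellTiter-Glo and resazurin assay, with a stated time of 72 h (on this read-out lower numbers stand for an effect already at smaller amounts and higher numbers for an effect only at larger amounts of compound), compound 3 gives > 26000 nM, which is a limit of the assay rather than a measured number. Two related compounds carry other groups on the same aromatic carbon: compound 1, `CC(C)N(Cc1cccc(OCCCCCC(=O)O)c1)C(=O)c1ccc(-c2cccc(N(C)C)c2)cc1`, and compound 2, `CC(=O)c1cccc(-c2ccc(C(=O)N(Cc3cccc(OCCCCCC(=O)O)c3)C(C)C)cc2)c1`. In this assay compound 1 gives > 26000 nM, also a limit. In this assay compound 2 gives > 26000 nM, likewise a limit. Because all three values sit at the limit of > 26000 nM in this assay, at which 3 of the 3 values shown sit, the steps a step that the two limits leave unreadable from compound 1 to compound 2, a step that the two limits leave unreadable from compound 1 to compound 3 and a step that the two limits leave unreadable from compound 2 to compound 3 cannot be sized, and compound 3 stands exactly where the other two stand.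

Compound 4, `CC(C)N(Cc1cccc(OCCCCCC(=O)O)c1)C(=O)c1ccc(-c2ccoc2)cc1`, differs from compound 3 by furan-3-yl in place of 3-(isobutoxy)phenyl on an aromatic carbon. For the measured compounds named here, none of the measured steps shows a group on this aromatic carbon moving a value away from the limit, so no readable step beyond the scatter can be expected here. Compound 4 is therefore estimated to give 26000 nM, between 10000 nM and 80000 nM. That expectation corresponds to the step of a number no higher from compound 3 to compound 4 (the limit leaves the size open), most probably reported again only as a limit.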

Compound 4, half-maximal effective concentration: > 26000 nM
Compound 4 ended at the assay's limit; the forecaster's own chance of this, stated with the estimate: 80%; the middle value lies on the limit itself.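

The steps from compounds 1, 2 and 3 to compound 4 cannot be read, as all four compounds sit at the same assay limit: the limit of > 26000 nM in this assay, at which 4 of the 4 values shown sit.

The compounds shown leave open whether furan-3-yl or any other group on this aromatic carbon makes any difference in this assay.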